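The source may hold more compounds than are shown below. What is called first, only, known or untested is meant among the compounds shown, and "the series" means these compounds.

Compound 1 `Oc1ccccc1-c1cc(-c2ccccc2C(F)(F)F)cc(-c2ccccc2O)n1` gives 3970 nM in a functional assay on HCT-15 cells (Homo sapiens) for inhibition; on this read-out higher numbers stand for weaker inhibition and lower numbers for stronger inhibition. Compound 2 `Oc1cccc(-c2cc(-c3ccccc3C(F)(F)F)cc(-c3ccccc3O)n2)c1` carries one change, (3-hydroxyphenyl in place of 2-hydroxyphenyl on an aromatic carbon), and in this assay compound 2 gives 9010 nM, so that change made a 2.3-fold higher number from compound 1 to compound 2 (0.36 log units; beyond the scatter). Within the data shown here, compound 3 `Oc1cccc(-c2cc(-c3ccccc3OC(F)(F)F)cc(-c3ccccc3O)n2)c1` gives 3240 nM, and the single change from compound 2 gave a 2.8-fold lower number from compound 2 to compound 3 (0.44 log units; beyond the scatter). How the core of compound 3 differs from that of compound 1 is not broken down here.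

Compound 4 `Oc1cccc(-c2cc(-c3ccccc3OC(F)(F)F)cc(-c3cccc(O)c3)n2)c1` has not yet been measured. It carries 3-hydroxyphenyl in place of 2-hydroxyphenyl on an aromatic carbon. The surroundings differ from the earlier case: in compound 1 the carbon is meta to a 2-(trifluoromethyl)phenyl group and meta to a 2-hydroxyphenyl group, in compound 3 it is meta to a 3-hydroxyphenyl group and meta to a large group, so this is the same kind of change, not the same one. The step from compound 3 to compound 4 is expected to be a 2.3-fold higher number from compound 3 to compound 4 (0.36 log units; beyond the scatter), because the same kind of change gave a 2.3-fold higher number from compound 1 to compound 2 (0.36 log units; beyond the scatter). Compound 4 is therefore estimated at 7500 nM, likely between 3500 nM and 16000 nM.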

Compound 4, half-maximal inhibitory concentration: 4220 nM
Compound 4: middle estimate off by 1.8-fold (0.25 log units), on the high side; the range from low to high includes it.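

Putting 3-hydroxyphenyl in place of 2-hydroxyphenyl on the core of compound 3 gave a 1.3-fold higher number from compound 3 to compound 4 (0.11 log units; within the scatter) in this assay. Set beside the earlier case, the two steps do not differ by more than the usual scatter allows: the same change on two cores in this assay, a 2.3-fold higher number (0.36 log units; beyond the scatter) from compound 1 to compound 2 and a 1.3-fold higher number (0.11 log units; within the scatter) from compound 3 to compound 4, 1.7-fold (0.24 log units) apart, within the scatter of two such steps. As far as these data can tell, the change carries from one core to the other, but two steps cannot show that it always behaves alike, nor whether it has any real effect on the core of compound 3.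

The compounds shown leave open what happens when an amine, a carboxylic acid or a methoxy group stands in place of the hydroxyl on these phenyl rings.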